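Diarylmethyl replacement on a thiazole acetic acid scaffold

The compounds below may be only part of what the source reports. "The series", "measured", "known", "first", "only" and "open" are said of these compounds alone.

Of the compounds shown here, three sharing one core have been measured in an in vitro functional assay on HEK285-7 cells for antagonist activity at prostaglandin D2 receptor 2 (Homo sapiens), read by BRET and beta-arrestin recruitment; a lower number here means a stronger inhibitor, a higher number a weaker inhibitor. Compound 1, `O=C(O)Cc1sc(NC(=O)c2ccccc2)nc1-c1ccc(Cl)cc1`, gives 870 nM. Compound 2, `O=C(O)Cc1sc(CSc2ccccc2)nc1-c1ccc(Cl)cc1`, gives 450 nM. Compound 3, `O=C(O)Cc1sc(C(Cc2ccccc2)c2ccccc2)nc1-c1ccc(Cl)cc1`, gives 510 nM. The number for compound 3 lies within the scatter of both compound 2 and compound 1, so the three values show no separation that can be read as a difference in activity among them.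

The step to compound 4, `COc1ccc(C(c2ccccc2)c2nc(-c3ccc(Cl)cc3)c(CC(=O)O)s2)cc1`, is a single exchange: 4-methoxyphenyl in place of benzyl on a saturated chain carbon bound to two aromatic carbons. Both compound 3 and compound 4 therefore carry two aromatic rings on the same saturated chain carbon, and the exchange only trades one of them for the other. Among the compounds with values here, no pair among the measured compounds shares a step of this kind, so there is no measured change on which to base a direction. With the three measured values lying within the scatter of one another and the exchange being a small one in count of atoms, a step no larger than the scatter is expected, with no direction favoured; the expected step is a 1.0-fold lower number from compound 3 to compound 4 (0.01 log units; within the scatter). Compound 4 is accordingly estimated at 500 nM, with a plausible range from 200 nM to 1300 nM.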

Compound 4, half-maximal inhibitory concentration: 76 nM
The estimate for compound 4 lay 6.6-fold (0.82 log units) above the measured number; the measured number lies below the stated range.
By their numbers in this assay, from the lowest: compound 4; then compounds 2, 3 and 1 (each within the scatter of the next).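

In this assay, putting 4-methoxyphenyl in place of benzyl on a saturated chain carbon bound to two aromatic carbons gives a 6.7-fold lower number from compound 3 to compound 4 (0.83 log units; beyond the scatter), a step beyond the scatter. This shows that the position is sensitive to which aromatic group it carries, even though the leaving and entering groups each hold one six-membered aromatic ring of carbon only and are close in heavy-atom count; the entering group has one hydrogen-bond acceptor and the leaving group none. Nothing at hand accounts for the size or direction of this step.

The single exchange alters both how the ring is attached to the chain carbon and what the ring carries, so the compounds shown leave open which of these changes matters, and whether plain phenyl in place of 4-methoxyphenyl would keep the lower number. They also leave open whether the oxygen itself counts, a question that 4-hydroxyphenyl, 4-ethoxyphenyl or 4-methylphenyl at the same carbon would address.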